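Stilbene carboxylic acids: cytotoxicity notes, compound 3 pending

This account rests on a few compounds, and the source may have more. Where it says the series, first, only, none or still open, it means among the compounds named here.

Measured so far:
compound 1 `O=C(O)c1c(O)cc(Cl)cc1C=Cc1ccc2ccccc2c1`: 38000 nM
compound 2 `COc1cc(C=Cc2ccc3ccccc3c2)c(C(=O)O)c(OC)c1`: > 100000 nM

Compound 2 stands at a limit in an ADME assay on HEK293 cells (Homo sapiens) for cytotoxicity, read by resazurin assay, with a stated time of 24 h; a higher number here means that more compound is tolerated, a lower number that less compound is tolerated: its result of > 100000 nM is a limit of the assay, not a number. Compound 1 gives a number in this assay, 38000 nM, and carries a chloro group where compound 2 carries one of its methoxy groups.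

Compound 3 `COc1cc(Cl)cc(C=Cc2ccc3ccccc3c2)c1C(=O)O` is not yet measured. It differs from compound 2 by chloro in place of methoxy on an aromatic carbon; the chloro enters on an aromatic carbon of a six-membered aromatic ring of carbon only, para to the carboxy group. Among the measured compounds shown here, no measured step of this kind is at hand, so the size of the step is open. Compound 1, which carries chloro, gives 38000 nM. Compound 2 sits at the limit (the limit of > 100000 nM in this assay, at which 1 of the 2 values shown sits). The expectation for compound 3 is a modest lowering, an at least 1.4-fold lower number from compound 2 to compound 3 (0.15 log units; that floor lies within the scatter), with the estimate 70000 nM in a range of 30000 nM to 150000 nM, and a fair chance that only a limit is returned.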

Compound 3, half-maximal cytotoxic concentration: 93000 nM
Compound 3: the middle estimate sits 1.3-fold (0.12 log units) below what was measured; the measured number falls inside the stated range.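

In this assay, chloro in place of methoxy on this aromatic carbon, para to the carboxy group, now gives a reading, though only as a floor: an at least 1.0-fold lower number from compound 2 to compound 3 (0.03 log units; that floor lies within the scatter). Compound 2 is a limit of the assay and not a number, which leaves the true size of this step unknown: the limit of > 100000 nM in this assay, at which 1 of the 3 values shown sits. Methyl in place of hydrogen on the oxygen, with the chloro kept, gives a 2.4-fold higher number from compound 1 to compound 3 (0.39 log units; beyond the scatter), so among these compounds the only step beyond the scatter is the one on that oxygen.

Open, from the compounds shown here alone, is whether an amine or a nitrile on the same carbon would read like chloro or methoxy. Also open, going by these compounds, is whether a longer chain on the oxygen, such as ethyl in place of methyl, would extend the step seen on that oxygen.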